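A few compounds are considered here, and "the series" means these few. Any claim that something is new, unique, unknown or untested is made for them only; others in the source may bear on it.

Measured so far in a functional assay on DLD-1 cells (Homo sapiens) for cytotoxicity, with a stated time of 48 h (on this read-out lower numbers stand for stronger inhibition and higher numbers for weaker inhibition), are three compounds:
- compound 1 `C[S+]([O-])/C=C/c1cc(=O)c2ccccc2o1` gives 8000 nM
- compound 2 `CCCCC(=O)Oc1ccc2oc(/C=C/[S+](C)[O-])cc(=O)c2c1` gives 6700 nM
- compound 3 `CC(C)CCOc1ccc2oc(/C=C/[S+](C)[O-])cc(=O)c2c1` gives 4100 nM

Compound 3 cannot be told apart from the other two, since the data show a 2.0-fold lower number from compound 1 to compound 3 (0.29 log units; within the scatter) and a 1.6-fold lower number from compound 2 to compound 3 (0.21 log units; within the scatter) as its steps. Compound 4 `COc1ccc2oc(/C=C/[S+](C)[O-])cc(=O)c2c1` carries methoxy where compound 3 carries isopentyloxy. This change hydrogen in place of isobutyl on a saturated chain carbon bound to an oxygen on an aromatic ring amounts to hydrogen in place of isobutyl on a saturated chain carbon bound to an oxygen on an aromatic ring. The nearest evidence is the step to isopentyloxy from the bare aromatic carbon, already given above, and a 1.2-fold lower number from compound 1 to compound 2 (0.08 log units; within the scatter) for a different group there. Both stayed small, so the expected result is a 1.3-fold higher number from compound 3 to compound 4 (0.13 log units; within the scatter) and nothing beyond the scatter. Compound 4 is estimated at 5500 nM with an expected range from 2800 nM to 10500 nM for repeat measurements.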

Compound 4, half-maximal inhibitory concentration: 5700 nM
Estimate against measurement, compound 4: 1.0-fold (0.02 log units) below; the range from low to high includes it.
By their numbers in this assay, from the lowest: compounds 3, 4, 2 and 1 (each within the scatter of the next).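

In this assay, trimming isopentyloxy to methoxy leaves the number within the scatter (a 1.4-fold higher number from compound 3 to compound 4 (0.14 log units; within the scatter)), and so does putting methoxy in place of (butylcarbonyl)oxy (a 1.2-fold lower number from compound 2 to compound 4 (0.07 log units; within the scatter)). Methoxy in place of hydrogen on the aromatic carbon also stays within it (a 1.4-fold lower number from compound 1 to compound 4 (0.15 log units; within the scatter)), so hydrogen and all three oxygen-linked groups at this position cannot be told apart. No measurement here offers an explanation for this.

As far as these compounds go, whether an amine or a carboxylic acid at this position would move the number beyond the scatter remains open. So does the effect of changes elsewhere on the shared core.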